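This account rests on a few compounds, and the source may have more. Where it says the series, first, only, none or still open, it means among the compounds named here.

Three compounds have numbers in an assay on isolated protein for inhibition of tyrosine-protein kinase receptor UFO (Homo sapiens), read by FRET and Z'-LYTE, with a stated time of 1.5 h; on this read-out lower numbers stand for stronger inhibition and higher numbers for weaker inhibition. Compound 1 `Cc1c(C(=O)Nc2ccc(Oc3ncnc4[nH]cc(-c5ccccc5)c34)c(F)c2)c(=O)c2cc(Cl)ccc2n1C` gives 1890 nM, compound 2 `CCc1ccc2c(c1)c(=O)c(C(=O)Nc1ccc(Oc3cccc4occ(-c5ccccc5)c34)c(F)c1)c(C)n2C` gives 192 nM, and compound 3 `CCc1ccc2c(c1)c(=O)c(C(=O)Nc1ccc(Oc3ccnc(C(N)=O)c3)c(F)c1)c(C)n2C` gives 4380 nM. Among these three, compound 1 stands second highest: compound 3 sits nearest with a higher number, compound 2 furthest with a lower number, and both gaps lie beyond the scatter. Compound 4 `Cc1c(C(=O)Nc2ccc(Oc3ncnc4[nH]cc(-c5ccccc5)c34)c(F)c2)c(=O)c2cc(C(C)(C)C)ccc2n1C` has not yet been measured. It differs from compound 1 in one place (tert-butyl in place of chloro on an aromatic carbon). Among the measured compounds shown here, no measured pair shows this change on its own, so no step can be read from the data. Compound 4 is expected to stay close to compound 1, with a step of a 1.6-fold lower number from compound 1 to compound 4 (0.20 log units; within the scatter) estimated as a small lowering. In this assay compound 4 is estimated at 1200 nM, within a range from 400 nM to 4000 nM.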

Compound 4, half-maximal inhibitory concentration: 42 nM
Estimate against measurement, compound 4: 29-fold (1.46 log units) above; measured number below the stated range.
By their numbers in this assay, from the lowest: compound 4; then compound 2; then compound 1; then compound 3.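

In this assay, among the compounds shown here, this place on the six-membered aromatic ring of carbon only proves highly sensitive to its substituent: tert-butyl in place of chloro gives a 45-fold lower number from compound 1 to compound 4 (1.65 log units; beyond the scatter) and is the first one-place change that can be read here. The larger group of four carbons is therefore not merely tolerated at this position but gives the lower number. No available evidence accounts for the size of this step. The compounds shown leave open how an isopropyl group, a methoxy group or an amine would stand at this place. They also leave open whether the same change would give a similar step on another core.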